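This account rests on a few compounds, and the source may have more. Where it says the series, first, only, none or still open, it means among the compounds named here.

Measured compounds:
Compound 1, `C=CS(=O)(=O)N1CCN(c2ncnc3sc(-c4cn(S(=O)(=O)c5ccccc5)c5ccccc45)cc23)CC1`, gives 40400 nM in a functional assay on MDA-MB-231 cells (Homo sapiens) for antiproliferative activity, read by MTT assay, with a stated time of 48 h; on this read-out higher numbers stand for weaker inhibition and lower numbers for stronger inhibition.
Compound 2, `CN1CCN(c2ccc(-c3cc4c(N5CCN(S(=O)(=O)/C=C/c6ccccc6)CC5)ncnc4s3)cc2)CC1`, gives 5900 nM in this assay.

Of these two numbers, compound 2 holds the lowest; compound 1 gives a higher number, and the gap between the two lies beyond the usual scatter, so compound 2 is the stronger inhibitor of the pair. Going by the values given here, no two measured compounds differ in only one place, so there is no measured step to lean on for the next change.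

Compound 3, `CN1CCN(c2ccc(-c3cc4c(N5CCN(C(=O)Nc6ccc(F)cc6F)CC5)ncnc4s3)cc2)CC1`, has not yet been measured. It differs from compound 2 in one place: (2,4-difluorophenyl)carbamoyl in place of (2-phenylethenyl)sulfonyl on an amine nitrogen in a ring. The group that leaves carries 3 double bonds outside aromatic rings and 2 hydrogen-bond acceptors; the group that enters carries 1 double bond outside aromatic rings, 1 hydrogen-bond donor and 1 hydrogen-bond acceptor, with two fluorine atoms on its ring.

Since nothing measured shows how this kind of exchange plays out, a small step toward weaker inhibition is expected, a 1.5-fold higher number from compound 2 to compound 3 (0.18 log units; within the scatter), with wide uncertainty. Compound 3 is estimated at 9000 nM, within a range from 2000 nM to 40000 nM.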

Compound 3, half-maximal inhibitory concentration: 11400 nM
Beside the measured number, compound 3's estimate is 1.3-fold (0.10 log units) below it, and the stated range covers the measured number.
By their numbers in this assay, from the lowest: compounds 2 and 3 (each within the scatter of the next); then compound 1.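

In this assay, going by these compounds alone, this is the first exchange that can be read at this amine nitrogen, and it gives a 1.9-fold higher number from compound 2 to compound 3 (0.29 log units; within the scatter). On this read-out, then, (2-phenylethenyl)sulfonyl and (2,4-difluorophenyl)carbamoyl cannot be told apart, even though the entering group swaps the sulfonyl link for a carbonyl link, brings a hydrogen-bond donor and carries two fluorine atoms on its ring, while the heavy-atom count stays the same. No measurement shown offers an explanation for this result.

The compounds shown leave open what an unsubstituted phenylcarbamoyl group would do on this ring nitrogen, so the contribution of the two fluorine atoms cannot be separated from that of the carbamoyl link, and a much smaller group such as acetyl or a longer chain ending in an amine could still show whether this position responds to larger changes. From the compounds shown here alone, it also remains open whether the same exchange would behave alike on a compound carrying the other large group found in compound 1, in place of the methylpiperazine-bearing phenyl group shared by compound 2 and compound 3.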